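Carboxy in place of fluoro on compound 1

The compounds below may be only part of what the source reports. "The series", "measured", "known", "first", "only" and "open" are said of these compounds alone.

In a physicochemical assay for acid dissociation, compound 1 (`NS(=O)(=O)c1ccc(SCCO)c(F)c1`) gives 9.76, compound 2 (`NS(=O)(=O)c1ccc(SCCCO)c(F)c1`) gives 9.64 and compound 3 (`NS(=O)(=O)c1ccc(SCCCCO)c(F)c1`) gives 9.82, so compound 1 stands level with both others within the scatter. Compound 4 (`NS(=O)(=O)c1ccc(SCCO)c(C(=O)O)c1`) has carboxy in place of fluoro on an aromatic carbon, ortho to a (2-hydroxyethyl)sulfanyl group and meta to a sulfamoyl group: carboxy in place of fluoro on an aromatic carbon. The measured steps, a number 0.12 log units lower from compound 1 to compound 2 (within the scatter), a number 0.06 log units higher from compound 1 to compound 3 (within the scatter) and a number 0.18 log units higher from compound 2 to compound 3 (within the scatter), all change the chain, and none changes the aromatic substituent. Among the compounds with values here, they therefore bear only indirectly, and no measured step covers carboxy. A slight rise, not clearly beyond the scatter, is expected. The estimated step is a number 0.24 log units higher from compound 1 to compound 4 (within the scatter). Compound 4 is expected at 10, with an estimated range of 9.4 to 10.6.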

Compound 4, acid dissociation constant: 10.5
The estimate for compound 4 lay 0.50 log units below the measured number; the measured number falls inside the stated range.
By their numbers in this assay, from the lowest: compounds 2, 1 and 3 (each within the scatter of the next); then compound 4.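

In this assay, carboxy in place of fluoro on the aromatic carbon ortho to a (2-hydroxyethyl)sulfanyl group and meta to a sulfamoyl group gives a number 0.74 log units higher from compound 1 to compound 4 (beyond the scatter). Within the data shown here, this is the first step beyond the scatter: the chain changes among compound 1, compound 2 and compound 3 all stayed within it. Nothing available explains this step. As far as these compounds go, whether a methyl ester or a primary amide on this aromatic carbon gives a step of similar size remains open, as does whether carboxy gives the same step on the longer chains of compound 2 and compound 3.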